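The source may report more compounds than this note shows. Statements on the series, on what has been measured and on what is new or still open speak of the compounds shown alone.

In a functional assay on L1210 cells (Mus musculus) for inhibition, with a stated time of 96 h (on this read-out higher numbers stand for weaker inhibition and lower numbers for stronger inhibition), compound 1 (`CCCNCCCNCCCN`) gives 100000 nM, compound 2 (`CCCNCCCNCCCCN`) gives 28000 nM and compound 3 (`CCCNCCCCNCCCNCCC`) gives 33000 nM. That places the third value within the scatter of the second, a 1.2-fold higher number from compound 2 to compound 3 (0.07 log units; within the scatter), and apart from the first, a 3.0-fold lower number from compound 1 to compound 3 (0.48 log units; beyond the scatter). The next structure is compound 4 (`CCCNCCCCNCCCCNCCC`), with this change: (propylamino)methyl in place of propylamino on a saturated chain carbon, three bonds along the chain from an amine nitrogen. The closest measured parallel is the replacement of amino by aminomethyl at the same kind of place, a modest step, a 3.6-fold lower number from compound 1 to compound 2 (0.55 log units; beyond the scatter). The propyl step adds nothing beyond the scatter, a 1.2-fold higher number from compound 2 to compound 3 (0.07 log units; within the scatter). A similar modest drop in this assay is therefore expected, a 2.4-fold lower number from compound 3 to compound 4 (0.37 log units; beyond the scatter). Compound 4 is estimated at 14000 nM, with an expected range of 5000 nM to 40000 nM.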

Compound 4, half-maximal inhibitory concentration: 6000 nM
Compound 4: the middle estimate sits 2.3-fold (0.37 log units) above what was measured; measured number inside the range.
By their numbers in this assay, from the lowest: compound 4; then compounds 2 and 3 (each within the scatter of the next); then compound 1.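

In this assay the replacement of propylamino by (propylamino)methyl on a saturated chain carbon, three bonds along the chain from an amine nitrogen, gives a 5.5-fold lower number from compound 3 to compound 4 (0.74 log units; beyond the scatter) and so remains a modest step. The added carbon therefore lowers the number with the propyl-bearing group as well as with the amino group of compounds 1 and 2. Nothing available accounts for this step.

Still open, going by these compounds, is whether a longer chain, such as (propylamino)ethyl, lowers the number further. On these data alone, the effect of a hydroxyl group in place of this amine is also open.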